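This account rests on a few compounds, and the source may have more. Where it says the series, first, only, none or still open, it means among the compounds named here.

Measured so far:
compound 1, `CCCc1cc(OCC(=O)Nc2cc(C)cc(C)c2)c2cc(OC)ccc2n1`: 6.44
compound 2, `COc1cccc(NC(=O)COc2cc(C)nc3ccc(OC)cc23)c1`: 4.49

Both compounds were run in a physicochemical assay for lipophilicity, read by HPLC, in phosphate buffer, measured as chromatographic lipophilicity, at pH 7.4; on this read-out lower numbers stand for lower lipophilicity and higher numbers for higher lipophilicity. Compound 1, `CCCc1cc(OCC(=O)Nc2cc(C)cc(C)c2)c2cc(OC)ccc2n1`, gives 6.44 in this assay. Compound 2, `COc1cccc(NC(=O)COc2cc(C)nc3ccc(OC)cc23)c1`, gives 4.49 in this assay, which is the lower of the two numbers; its nearest neighbour is compound 1, and the gap between them is beyond the scatter. The two compounds differ in more than one place, so no single step between them is shown, and only the two values themselves can be compared.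

Compound 3, `COc1ccc2nc(C)cc(OCC(=O)Nc3ccc(Cl)cc3)c2c1`, has not yet been measured in this assay. Compared with compound 2 it carries one change: 4-chlorophenyl in place of 3-methoxyphenyl on an amide-type nitrogen. For the measured compounds named here, no step between measured compounds describes this kind of change here, so the expectation rests on compound 2 alone. From the value of compound 2 in this assay, 4.49, a moderate rise is expected for compound 3, a step of about a number 0.81 log units higher from compound 2 to compound 3 (beyond the scatter), clearly beyond the scatter. For compound 3 the estimate in this assay is therefore 5.3, with a likely range from 4.8 to 5.8.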

Compound 3, distribution coefficient: 5.15
For compound 3 the middle estimate is 0.15 log units above the measured one; measured number inside the range.
By their numbers in this assay, from the lowest: compound 2; then compound 3; then compound 1.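

In this assay, for the compounds shown here, the swap of 3-methoxyphenyl for 4-chlorophenyl on the amide-type nitrogen gives a number 0.66 log units higher from compound 2 to compound 3 (beyond the scatter) and is the first comparison here in which only one place differs, so it shows that the group on this nitrogen can by itself move the read-out beyond the scatter. The step is modest, yet it bundles two differences: an oxygen-bearing methoxy group gives way to a chlorine atom, and the ring position of the substituent changes too, so the size of the step cannot be divided between them. Nothing in the data shown accounts for the step, which therefore stands as an observation without an explanation.

The compounds shown leave open how much of the step belongs to the kind of substituent and how much to its ring position, a question that 3-chlorophenyl or 4-methoxyphenyl on the same nitrogen would help to answer. They also leave open how far the read-out would move with a phenyl ring carrying an amine or a carboxylic acid at this place.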